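A few compounds are considered here, and "the series" means these few. Any claim that something is new, unique, unknown or untested is made for them only; others in the source may bear on it.

Working notes on the series in a functional assay on MCF cells (Homo sapiens) for antiproliferative activity, with a stated time of 72 h; a lower number here means a stronger inhibitor, a higher number a weaker inhibitor. Compound 1 `OC[C@H]1O[C@@H](n2cnc3c(NCc4ccccc4Cl)ncnc32)[C@H](O)[C@@H]1O` is reported only as a limit, > 166000 nM. Compound 2 `COc1cccc(CNc2ncnc3c2ncn3[C@@H]2O[C@H](CO)[C@@H](O)[C@H]2O)c1` is also reported only as a limit, > 166000 nM. Compound 3 `OC[C@H]1O[C@@H](n2cnc3c(NCc4ccc(F)cc4F)ncnc32)[C@H](O)[C@@H]1O` likewise has no number, only the limit > 166000 nM.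

The next structure is compound 4 `Cc1ccc(O)c(CNc2ncnc3c2ncn3[C@@H]2O[C@H](CO)[C@@H](O)[C@H]2O)c1`, which shares the core of compound 3 and differs in one group: 2-hydroxy-5-methylphenyl in place of 2,4-difluorophenyl on a saturated chain carbon bound to a nitrogen on an aromatic ring. Cut one bond further out, the same difference reads 2,4-difluorobenzyl to 2-hydroxy-5-methylbenzyl.

Going by the values given here, three measured steps bear on this change, all at the same place: a step that the two limits leave unreadable from compound 1 to compound 2, a step that the two limits leave unreadable from compound 1 to compound 3 and a step that the two limits leave unreadable from compound 2 to compound 3. None of them has a readable size, so the series offers no measured effect of changing this group. Compound 3 stands with the other two at the limit of > 166000 nM in this assay, at which 3 of the 3 values shown sit, so no step beyond the scatter is expected in this assay. The entering group is unlike the three seen so far, so any movement that does occur is expected toward a stronger inhibitor. The expected step is an at least 1.1-fold lower number from compound 3 to compound 4 (0.04 log units; that floor lies within the scatter). Compound 4 is estimated at 150000 nM, with an expected range of 30000 nM to 250000 nM, and a report as a limit alone is the likeliest outcome.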

Compound 4, half-maximal inhibitory concentration: > 166000 nM
Compound 4: a limit, no number; the forecaster's own chance of this, stated with the estimate: 70%; at least 1.1-fold (0.04 log units) between middle value and limit.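

No new step can be read: compound 4, like compound 1, compound 2 and compound 3, is reported only as a limit, so the steps joining it to those three cannot be sized. The compounds shown leave open whether changing this group alters the read-out in this assay at all, since all of them share one limit: the limit of > 166000 nM in this assay, at which 4 of the 4 values shown sit.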